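The source may hold more compounds than are shown below. What is called first, only, known or untested is meant among the compounds shown, and "the series" means these compounds.

Measured so far in a functional assay on the whole organism (plasma, strain Sprague-Dawley) with Rattus norvegicus as the target, with a stated time of 2 h, at a dose of 100 mg/kg by the oral route; a higher number here means a stronger effect of the compound at the dose given, a lower number a weaker effect:
- compound 1, `c1ccc(C(/N=C2\CCCCCN2)C2CCC2)cc1`: 44%
- compound 2, `c1ccc(C(/N=C2\CCCCCN2)C2CCCCC2)cc1`: 0%
- compound 3, `c1coc(C/N=C2\CCCCCN2)c1`: 0%

Compound 3 stands level with compound 2 at the digits printed, and the two together are the lowest of the three numbers; compound 1 lies higher by a margin beyond the scatter. Among the measured compounds shown here, the only step between measured compounds that differ in one place is a number 44 percentage points lower from compound 1 to compound 2 (beyond the scatter), a large fall on enlarging the saturated group at the carbon bound to an aromatic carbon and a double-bonded nitrogen.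

Compound 4, `c1ccc(C(/N=C2\CCCCCN2)c2ccco2)cc1`, is not yet measured. It differs from compound 3 by phenyl in place of hydrogen on a saturated chain carbon bound to an aromatic carbon and a double-bonded nitrogen. For the measured compounds named here, no measured pair shows this particular exchange, so the step from compound 1 to compound 2 bears on it only loosely: it shows that the size of the group on that carbon matters, and that a carbon carrying both a phenyl and a small saturated ring can give a clear read-out, as in compound 1. The entering phenyl is aromatic rather than saturated, so the direction is uncertain.

Compound 4 is expected to give 15%, with a range from 0% to 45%. The expected step is a number 15 percentage points higher from compound 3 to compound 4 (beyond the scatter), modest and not confidently beyond the scatter.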

Compound 4, a percentage reported as inhibition, in the whole organism at one dose (the size of the read-out at that dose, not a potency): 52%
Beside the measured number, compound 4's estimate is 37 percentage points below it; the measured number lies above the stated range.
By their numbers in this assay, from the lowest: compounds 2 and 3 (each within the scatter of the next); then compounds 1 and 4 (each within the scatter of the next).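

Working from this assay, phenyl in place of hydrogen on a saturated chain carbon bound to an aromatic carbon and a double-bonded nitrogen gives a number 52 percentage points higher from compound 3 to compound 4 (beyond the scatter) and is the first direct reading of this change: with furan-2-yl already on that carbon, a second group there can turn an empty read-out into a clear one. With phenyl held constant on the same carbon, furan-2-yl in place of cyclohexyl gives a number 52 percentage points higher from compound 2 to compound 4 (beyond the scatter), whereas furan-2-yl in place of cyclobutyl gives a number 8 percentage points higher from compound 1 to compound 4 (within the scatter), so furan-2-yl and cyclobutyl stand level here, and the position tolerates an aromatic ring as well as a small saturated one, while cyclohexyl stays the exception among the groups shown. Nothing available on these compounds accounts for any of these steps.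

Still open, as far as these compounds go, is whether phenyl is specifically required in the entering place, or whether a methyl, a benzyl or a pyridin-3-yl group on that carbon would serve as well. Also open, from the compounds shown here alone, is whether thiophen-2-yl or cyclopentyl would hold the read-out alongside phenyl, and whether the stronger effects seen at this single dose would persist at other doses.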